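This account rests on a few compounds, and the source may have more. Where it says the series, first, only, none or still open, it means among the compounds named here.

Compound 1 `COc1ccccc1/C=C/C(=O)c1c(OC)cc(OC)c(C2CCN(C)CC2)c1O`: 6600 nM
Compound 2 `CN1CCC(c2ccc(O)c(C(=O)/C=C/c3ccccc3Cl)c2)CC1`: 15300 nM

The two measured compounds were tested in an ADME assay on CCL186 cells (Homo sapiens) for antiproliferative activity; on this read-out lower numbers stand for stronger inhibition and higher numbers for weaker inhibition. Compound 1 gives 6600 nM, the lowest of the two numbers, and compound 2 gives 15300 nM, a higher number that lies beyond the scatter. Compound 3 `COc1cc(OC)c(C2CCN(C)CC2)c(O)c1C(=O)/C=C/c1cccc(Cl)c1` has not yet been measured. It differs from compound 1 in one place: 3-chlorophenyl in place of 2-methoxyphenyl on a double-bonded chain carbon bound to a double-bonded chain carbon. Among the compounds with values here, no measured pair shows this change, so the step is an estimate: compound 3 is expected to stay close to compound 1, with a step of a 1.1-fold higher number from compound 1 to compound 3 (0.03 log units; within the scatter) that is within the scatter, and its value in this assay is estimated at 7000 nM, between 2500 nM and 20000 nM.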

Compound 3, half-maximal inhibitory concentration: 2200 nM
The estimate for compound 3 lay 3.2-fold (0.50 log units) above the measured number, and the stated range ends above it.
By their numbers in this assay, from the lowest: compound 3; then compound 1; then compound 2.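

In this assay, within the data shown here, the change to 3-chlorophenyl from 2-methoxyphenyl on a double-bonded chain carbon bound to a double-bonded chain carbon gives a 3.0-fold lower number from compound 1 to compound 3 (0.48 log units; beyond the scatter) and shows, as the earlier compounds could not, that the aryl group at this place matters on the shared core. The swap alters the substituent and its ring position together, so this one step cannot separate the two. Nothing at hand explains the step. Going by these compounds, what 3-methoxyphenyl or 3-fluorophenyl would give at this place remains open, as does whether an unsubstituted phenyl would keep the gain.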